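Swapping the Nitrophenyl Anilino Group for a Fluorophenyl One

The source may hold more compounds than are shown below. What is called first, only, known or untested is meant among the compounds shown, and "the series" means these compounds.

Compound 1 `N#Cc1c(Nc2cccc(C(F)(F)F)c2)nc(SCc2cn(Cc3ccccc3Cl)nn2)nc1-c1ccccc1`: 22800 nM
Compound 2 `Cc1cccc(Nc2nc(SCc3cn(Cc4ccccc4Cl)nn3)nc(-c3ccccc3)c2C#N)c1`: 16200 nM
Compound 3 `N#Cc1c(Nc2cccc([N+](=O)[O-])c2)nc(SCc2cn(Cc3ccccc3Cl)nn2)nc1-c1ccccc1`: 43100 nM

In a functional assay on MGC-803 cells (Homo sapiens) for inhibition, read by MTT assay, with a stated time of 72 h (on this read-out lower numbers stand for stronger inhibition and higher numbers for weaker inhibition), compound 3 gives the highest of the three numbers. The two measured steps leading to it are a 1.9-fold higher number from compound 1 to compound 3 (0.28 log units; within the scatter) and a 2.7-fold higher number from compound 2 to compound 3 (0.42 log units; beyond the scatter). Compound 4 `N#Cc1c(Nc2ccccc2F)nc(SCc2cn(Cc3ccccc3Cl)nn2)nc1-c1ccccc1` differs from compound 3 by 2-fluorophenyl in place of 3-nitrophenyl on a nitrogen on an aromatic ring. Both measured steps bear on this change, since each exchanges the group on the anilino ring, and each exchange away from nitro went with a lower number, one within the scatter and one modestly beyond it. Nothing measured covers a 2-fluorophenyl group itself. A modest step to a lower number is therefore expected, a 2.0-fold lower number from compound 3 to compound 4 (0.29 log units; within the scatter). Compound 4 is estimated to give 22000 nM in this assay, with a range from 9000 nM to 55000 nM.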

Compound 4, half-maximal inhibitory concentration: 7580 nM
Compound 4: middle estimate off by 2.9-fold (0.46 log units), on the high side, outside the stated range (below it).
By their numbers in this assay, from the lowest: compound 4; then compounds 2, 1 and 3 (each within the scatter of the next, the first and the last beyond it).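

Under this assay the 2-fluorophenyl group gives a 5.7-fold lower number from compound 3 to compound 4 (0.75 log units; beyond the scatter) and a 2.1-fold lower number from compound 2 to compound 4 (0.33 log units; beyond the scatter) and also a 3.0-fold lower number from compound 1 to compound 4 (0.48 log units; beyond the scatter) so compound 4 stands apart from all three earlier compounds. No exchange among 3-nitrophenyl, 3-methylphenyl and 3-(trifluoromethyl)phenyl gave a step as large as the one from 3-nitrophenyl to 2-fluorophenyl. Nothing given here accounts for this difference.

The change alters both the group and its place on the ring, so the two cannot be separated. From the compounds shown here alone, how 3-fluorophenyl or 2-methoxyphenyl would compare with compound 4 remains open.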